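Bromo for nitro on a second core in the series

The source may report more compounds than this note shows. Statements on the series, on what has been measured and on what is new or still open speak of the compounds shown alone.

Two cores carry the same aryl substitution. Compound 1 `N#CCC1=NN=C(c2ccc(Br)cc2)C(CC(=O)c2ccc([N+](=O)[O-])cc2)O1` and compound 2 `N#CCC1=NN=C(c2ccc([N+](=O)[O-])cc2)C(CC(=O)c2ccc([N+](=O)[O-])cc2)O1` share one core and differ only in the group on the aromatic carbon (bromo in place of nitro on an aromatic carbon). In a functional assay on THP-1 cells (Homo sapiens) for inhibition, read by sulforhodamine B assay, with a stated time of 48 h (on this read-out higher numbers stand for weaker inhibition of growth and lower numbers for stronger inhibition of growth), compound 2 gives 33000 nM, while compound 1 gives 20000 nM; the step is a 1.7-fold lower number from compound 2 to compound 1 (0.22 log units; within the scatter), so nothing can be said about the order of these two.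

Compound 3 `N#CCC1=C(C#N)CC(c2ccc([N+](=O)[O-])cc2)=C(CC(=O)c2ccc([N+](=O)[O-])cc2)O1` sits on a different core; the difference between the two cores is not broken down here. In this assay compound 3 gives 10200 nM, which lies within the scatter of compound 1 but beyond it relative to compound 2.

Compound 4 `N#CCC1=C(C#N)CC(c2ccc(Br)cc2)=C(CC(=O)c2ccc([N+](=O)[O-])cc2)O1` is the bromo counterpart of compound 3 on this second core (bromo in place of nitro on an aromatic carbon). The change is the same as that from compound 2 to compound 1, made at the same place and in the same words. For the measured compounds named here, with only one earlier instance, and that one within the scatter, the expectation rests on the step of a 1.7-fold lower number from compound 2 to compound 1 (0.22 log units; within the scatter) on the first core and on the value measured for compound 3 10200 nM. The expected step is a 1.5-fold lower number from compound 3 to compound 4 (0.16 log units; within the scatter). Compound 4 is therefore estimated at 7000 nM in this assay, with an expected range from 3000 nM to 18000 nM.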

Compound 4, concentration for 50% growth inhibition: 12900 nM
The estimate for compound 4 lay 1.8-fold (0.27 log units) below the measured number; low and high end bracket the measured number.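

In this assay the change from nitro to bromo on the second core gives a 1.3-fold higher number from compound 3 to compound 4 (0.10 log units; within the scatter) and leaves compound 3 and compound 4 without an order. Neither step stands beyond the scatter, so the pairs give no sign that this change moves growth inhibition in either direction on either core, and the opposite directions of the two steps cannot be read as a real difference between the cores; two pairs also cannot show that the change would stay this small on any further core. Set side by side, the two steps show that the change carries from one core to the other with no difference that can be told apart from the scatter: the same change on two cores in this assay, a 1.7-fold lower number (0.22 log units; within the scatter) from compound 2 to compound 1 and a 1.3-fold higher number (0.10 log units; within the scatter) from compound 3 to compound 4, 2.1-fold (0.32 log units) apart, within the scatter of two such steps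

The compounds shown vary only one group on one aromatic ring, nitro or bromo, which leaves open whether another group at that place, such as an amine, a methoxy group or a carboxylic acid, would give a step beyond the scatter. Also open, on these data alone, is what a replacement of the other 4-nitrophenyl group, the one on the carbonyl side chain and common to all four compounds, would do, for instance by an amine or a chlorine on that ring.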